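A few compounds are considered here, and "the series" means these few. Any claim that something is new, unique, unknown or untested is made for them only; others in the source may bear on it.

Working notes on the series.

Compound 1 `CN1C(=O)C(C2CC2)N(C)c2nc(Nc3ccc(S(N)(=O)=O)cc3)ncc21` is the reference point here. Among the measured compounds shown here, in an assay on Sf9 cells for inhibition of serine/threonine-protein kinase 4 (Homo sapiens), read by luminescence and ADP-Glo, with a stated time of 1 h, in the presence of a further agent that is not named here (a higher number here means a weaker inhibitor, a lower number a stronger inhibitor), compound 1 gives 136 nM, the lowest of the three numbers measured so far, with every step away from it beyond the scatter. Compound 2 `CN1C(=O)C(c2cccc(C(F)(F)F)c2)N(C)c2nc(Nc3ccc(S(N)(=O)=O)cc3)ncc21` gives 2710 nM, and compound 3 `Cc1c(F)cccc1C1C(=O)N(C)c2cnc(Nc3ccc(S(N)(=O)=O)cc3)nc2N1C` gives 419 nM.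

The step to compound 4 `CN1C(=O)C(c2cccs2)N(C)c2nc(Nc3ccc(S(N)(=O)=O)cc3)ncc21` is thiophen-2-yl in place of cyclopropyl on a saturated ring carbon. Two measured steps from the same carbon bear on it: a 20-fold higher number from compound 1 to compound 2 (1.30 log units; beyond the scatter), and a 3.1-fold higher number from compound 1 to compound 3 (0.49 log units; beyond the scatter). Both aromatic replacements of the cyclopropyl weaken inhibition in this assay, though by quite different amounts, and a 6.5-fold lower number from compound 2 to compound 3 (0.81 log units; beyond the scatter) shows how much the choice of aromatic ring matters. Compound 4 is expected to follow the same direction because both a 20-fold higher number from compound 1 to compound 2 (1.30 log units; beyond the scatter) and a 3.1-fold higher number from compound 1 to compound 3 (0.49 log units; beyond the scatter) run that way, with the thiophen-2-yl more likely to sit near the smaller of the two measured losses than the larger.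

Compound 4 is therefore estimated to show a 2.8-fold higher number from compound 1 to compound 4 (0.45 log units; beyond the scatter), a modest weakening beyond the scatter rather than a large one. The estimate for compound 4 in this assay is 380 nM, with a plausible range from 130 nM to 1100 nM.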

Compound 4, half-maximal inhibitory concentration: 88 nM
For compound 4 the middle estimate is 4.3-fold (0.64 log units) above the measured one; the measured number lies below the stated range.
By their numbers in this assay, from the lowest: compounds 4 and 1 (each within the scatter of the next); then compound 3; then compound 2.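

In this assay, an aromatic ring on this saturated ring carbon does not by itself bring a loss: thiophen-2-yl in place of cyclopropyl leaves compounds 1 and 4 indistinguishable (a 1.5-fold lower number from compound 1 to compound 4 (0.19 log units; within the scatter)). The earlier compounds shown here could not show this, since both aromatic replacements among them lay beyond the scatter on the weaker side of compound 1, whereas the thiophen-2-yl stands well apart from both the 3-fluoro-2-methylphenyl (a 4.8-fold lower number from compound 3 to compound 4 (0.68 log units; beyond the scatter)) and the 3-(trifluoromethyl)phenyl (a 31-fold lower number from compound 2 to compound 4 (1.49 log units; beyond the scatter)). Among these four compounds, the losses therefore go with those two substituted phenyl groups and not with aromatic rings at this carbon as a class, and nothing available here accounts for the differences between them.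

The compounds shown leave open whether unsubstituted phenyl or thiophen-3-yl would stay with compounds 1 and 4 or fall with compound 3. They also leave open how this carbon would respond to a group of another kind, such as a primary amine, a carboxylic acid or a longer alkyl chain.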